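The source may report more compounds than this note shows. Statements on the series, on what has been measured and on what is new or still open speak of the compounds shown alone.

Compound 1 `C/C(=C\c1cc(-c2ccccc2)co1)C(N)=O`, compound 2 `C/C(=C\c1cc(-c2ccc(F)cc2)cs1)C(N)=O` and compound 3 `C/C(=C\c1cc(-c2ccc(S(C)(=O)=O)cc2)cs1)C(N)=O` were each tested in a functional assay on BGC-823 cells (Homo sapiens) for cytotoxicity, read by CCK-8 assay, with a stated time of 24 h; a higher number here means a weaker inhibitor, a lower number a stronger inhibitor. In this assay compound 1 reaches only the limit of the assay, > 50000 nM. In this assay compound 2 likewise gives only the limit, > 50000 nM. In this assay compound 3 also sits at the limit, > 50000 nM. Among the compounds with values here, the single one-place change among the measured set, a step that the two limits leave unreadable from compound 2 to compound 3, cannot be read in size or direction since both of its ends rest at the limit of > 50000 nM in this assay, at which 3 of the 3 values shown sit. Compound 3 thus stands nowhere in particular on the numbers shown: it is one of three values, all at the same limit.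

Compound 4 `C=Cc1ccc(-c2csc(/C=C(\C)C(N)=O)c2)cc1` is not yet measured. It differs from compound 3 by vinyl in place of methylsulfonyl on an aromatic carbon. Within the data shown here, no measured step bears on this exchange: the only step available was itself unreadable, and none of the three measured compounds carries a vinyl group. Nothing in the data points to a step of any size or direction in this assay. The expected step that the limit leaves unreadable from compound 3 to compound 4 is anchored only on the limit shared by all three measured compounds. Compound 4 is therefore expected to give about 60000 nM, with a likely range from 20000 nM to 200000 nM, and most probably to be reported again only as a limit.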

Compound 4, half-maximal inhibitory concentration: > 50000 nM
Compound 4: no number, only a limit (the forecaster's own chance of this, stated with the estimate: 80%); the middle value lies beyond the limit too.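

In this assay compound 4 gives > 50000 nM as a limit of the assay and not a number. Neither the step from compound 3 to compound 4 nor that from compound 2 to compound 4 can be read, since all their ends rest at one limit: the limit of > 50000 nM in this assay, at which 4 of the 4 values shown sit.

The compounds shown leave open whether any change to the shared core would give a readable number in this assay at all.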